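From an Oxane Side Chain to a Cyanophenyl Group

The source may hold more compounds than are shown below. What is called first, only, known or untested is meant among the compounds shown, and "the series" means these compounds.

Compound 2 `O=C(O)c1ccccc1-c1ccc(CCc2ncc(CC3CCOCC3)[nH]2)cc1` stands lowest of the three numbers in an in vitro functional assay on cells for agonist activity at Bombesin receptor subtype-3 (Homo sapiens), read by luminescence and calcium flux (on this read-out lower numbers stand for an effect already at smaller amounts and higher numbers for an effect only at larger amounts of compound), where compound 2 gives 338 nM. Compound 1 `CCCCc1cnc(C(CCC)Cc2ccc(-c3ccccc3C(=O)O)cc2)[nH]1` gives 1180 nM in this assay, and compound 3 `CCCCc1cnc(C(Cc2ccc(-c3ccccc3C(=O)O)cc2)C(C)C)[nH]1` gives 4620 nM. Within the data shown here, the single step within the set, a 3.9-fold higher number from compound 1 to compound 3 (0.59 log units; beyond the scatter), concerns a different part of the molecule and not the group at the far end of the chain. Compound 4 `N#Cc1ccc(Cc2cnc(CCc3ccc(-c4ccccc4C(=O)O)cc3)[nH]2)cc1` differs from compound 2 by 4-cyanophenyl in place of oxan-4-yl on a saturated chain carbon bound to an aromatic carbon. Among the measured compounds shown here, no measured step covers this exchange, so the data give no direction for it. The expected outcome is a step of a 1.2-fold higher number from compound 2 to compound 4 (0.07 log units; within the scatter), that is, nothing clearly beyond the scatter. The estimate for compound 4 is therefore 400 nM, with a range from 100 nM to 2000 nM.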

Compound 4, half-maximal effective concentration: 5890 nM
For compound 4 the middle estimate is 15-fold (1.17 log units) below the measured one, and the stated range ends below it.
By their numbers in this assay, from the lowest: compound 2; then compound 1; then compounds 3 and 4 (each within the scatter of the next).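

Among these compounds, the group on this saturated chain carbon, which no earlier step had touched, turns out to matter: in this assay 4-cyanophenyl in place of oxan-4-yl gives a 17-fold higher number from compound 2 to compound 4 (1.24 log units; beyond the scatter) and so counts as a large step. The two groups match in hydrogen-bond donors, hydrogen-bond acceptors and net charge, so those counts do not follow the change. No available evidence bears on what lies behind this step. The compounds shown leave open whether the step belongs to the nitrile or to the aromatic ring itself, which a plain phenyl group at this place would separate. As far as these compounds go, whether an amine such as piperidin-4-yl would behave like oxan-4-yl also stays open.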